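The compounds below may be only part of what the source reports. "The series", "measured", "known", "first", "only" and "open" are said of these compounds alone.

Working notes on the series, read in a functional assay on Hep 3B2 cells (Homo sapiens) for antiproliferative activity, read by MTT assay, with a stated time of 24 h; a lower number here means a stronger inhibitor, a higher number a weaker inhibitor. Compound 3 (`CCc1ccc2nc(C(=O)Nc3c(F)cc(-c4cccc(F)c4)cc3F)c(C)c(C(=O)O)c2c1`) gives 16900 nM. Within the data shown here, compound 2 (`Cc1ccc2nc(C(=O)Nc3c(F)cc(-c4cccc(F)c4)cc3F)c(C)c(C(=O)O)c2c1`) gives 31600 nM, within the scatter of compound 3, and these are the only two numbers available. Compound 1 (`Cc1c(C(=O)Nc2c(F)cc(-c3cccc(F)c3)cc2F)nc2ccc(F)cc2c1O`) reads > 100000 nM. That reading is a limit of this assay, not a number.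

Next is compound 4 (`Cc1c(C(=O)Nc2c(F)cc(-c3cccc(F)c3)cc2F)nc2ccc(F)cc2c1C(=O)O`). The change is fluoro in place of ethyl on an aromatic carbon of a six-membered aromatic ring of carbon only, part of a fused or bridged system of two rings: fluoro in place of ethyl on an aromatic carbon.

Among the measured compounds shown here, only one measured step touches this group: a 1.9-fold lower number from compound 2 to compound 3 (0.27 log units; within the scatter). That step lies within the scatter, so the data show little response in this assay to the move between methyl and ethyl. No fluoro group has been measured against an alkyl group at this place with everything else held constant, so the estimate is an extrapolation and its range stays wide.

For the measured compounds named here, because the only step at this place is a 1.9-fold lower number from compound 2 to compound 3 (0.27 log units; within the scatter), no shift beyond the scatter is expected, and the number may sit nearer that of compound 2. The expected step is a 1.5-fold higher number from compound 3 to compound 4 (0.17 log units; within the scatter).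

For compound 4 the estimated value is 25000 nM, with an expected range of 9000 nM to 70000 nM.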

Compound 4, half-maximal inhibitory concentration: 14700 nM
For compound 4 the middle estimate is 1.7-fold (0.23 log units) above the measured one; low and high end bracket the measured number.
By their numbers in this assay, from the lowest: compounds 4, 3 and 2 (each within the scatter of the next, the first and the last beyond it). At a limit, above all of these: compound 1.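

In this assay, fluoro in place of ethyl on an aromatic carbon gives a 1.1-fold lower number from compound 3 to compound 4 (0.06 log units; within the scatter), so this position accepts a halogen as readily as ethyl, the first sign that an alkyl group is not needed here. Against methyl the change gives a 2.1-fold lower number from compound 2 to compound 4 (0.33 log units; beyond the scatter), a modest step beyond the scatter, but compound 3 lies within the scatter of both compound 2 and compound 4, so the three compounds give no clear order among the groups at this place. Among these compounds, with fluoro held constant, carboxy in place of hydroxy on an aromatic carbon gives an at least 6.8-fold lower number from compound 1 to compound 4 (0.83 log units; beyond the scatter), the first direct comparison of these two groups, and the reading for compound 1 in that step is a limit, not a number: the limit of > 100000 nM in this assay, at which 1 of the 4 values shown sits.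

The compounds shown leave open how a chloro, a methoxy, an amine or a chain longer than ethyl would read at this place on the six-membered ring. Also open, on these data alone, is whether a primary amide or a methyl ester in place of the carboxy would give a number or a limit in this assay.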